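This account rests on a few compounds, and the source may have more. Where it says the series, first, only, none or still open, it means among the compounds named here.

Working notes on the series around compound 3 `COc1ccc([C@H]2CC(=O)N(c3ccccc3C(F)(F)F)C2)cc1OC1CCCC1` and the step to compound 4 `COc1ccc([C@H]2CC(=O)N(c3ccc(S(C)(=O)=O)cc3)C2)cc1OC1CCCC1`.

Compound 1 `COc1ccc([C@H]2CC(=O)N(C(=O)c3ccccc3)C2)cc1OC1CCCC1` carries benzoyl on the amide-type nitrogen in the ring; in a functional assay on HEK293 cells (Homo sapiens) for cytotoxicity (on this read-out lower numbers stand for higher toxicity in this test and higher numbers for lower toxicity in this test), compound 1 gives > 10000 nM, which is a limit of the assay and not a number. Compound 2 `COc1ccc([C@H]2CC(=O)N(c3ccccc3)C2)cc1OC1CCCC1` carries phenyl on that nitrogen; in this assay compound 2 gives > 10000 nM, again a limit. Compound 3 carries 2-(trifluoromethyl)phenyl on that nitrogen; in this assay compound 3 gives > 10000 nM, also a limit. Compound 3 thus stands where the whole set stands: the limit of > 10000 nM in this assay, at which 3 of the 3 values shown sit. The three steps between measured compounds are all unreadable for that reason: a step that the two limits leave unreadable from compound 1 to compound 2, a step that the two limits leave unreadable from compound 1 to compound 3 and a step that the two limits leave unreadable from compound 2 to compound 3.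

The change from compound 3 to compound 4: 4-(methylsulfonyl)phenyl in place of 2-(trifluoromethyl)phenyl on an amide-type nitrogen in a ring. Within the data shown here, the steps that bear on it are the two that exchange the group on the amide-type nitrogen in the ring, a step that the two limits leave unreadable from compound 1 to compound 2 and a step that the two limits leave unreadable from compound 1 to compound 3, and the one with trifluoromethyl in place of hydrogen on an aromatic carbon, a step that the two limits leave unreadable from compound 2 to compound 3. None gave a readable size and none moved any compound off the limit. No step beyond the scatter is therefore expected in this assay for compound 4. The step expected is a step that the limit leaves unreadable from compound 3 to compound 4. Compound 4 is expected to give about 20000 nM in this assay, within 8000 nM to 60000 nM, most probably reported once more as a limit.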

Compound 4, half-maximal cytotoxic concentration: > 10000 nM
Compound 4 ended at the assay's limit; the forecaster's own chance of this, stated with the estimate: 85%; the middle value lies beyond the limit too.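

In this assay, among these compounds, compound 4 also gives a limit and not a number, so no step among compound 1, compound 2, compound 3 and compound 4 can be read: the limit of > 10000 nM in this assay, at which 4 of the 4 values shown sit.

The compounds shown leave open how far benzoyl, phenyl, 2-(trifluoromethyl)phenyl and 4-(methylsulfonyl)phenyl on the amide-type nitrogen in the ring differ in this assay once values lie inside the measurable range.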